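Compound 1 to compound 4: a new side group

The source may report more compounds than this note shows. Statements on the series, on what has been measured and on what is new or still open speak of the compounds shown alone.

- Compound 1 `Nc1nc2ccc(-c3cccc(C(=O)Nc4cccc(C(F)(F)F)c4)c3)nc2s1`: > 10000 nM (a limit)
- Compound 2 `CC(=O)Nc1nc2ccc(-c3cccc(C(=O)Nc4cccc(C(F)(F)F)c4)c3)nc2s1`: > 10000 nM (a limit)
- Compound 3 `O=C(Nc1cccc(C(F)(F)F)c1)c1cccc(-c2ccc3nc(NC(=O)C4CCNCC4)sc3n2)c1`: > 10000 nM (a limit)

All three were measured in an ADME assay on BaF3 cells (Mus musculus) for cytotoxicity (on this read-out higher numbers stand for an effect only at larger amounts of compound and lower numbers for an effect already at smaller amounts), so compound 1 has no exact number, only a limit. The same holds across the set: the limit of > 10000 nM in this assay, at which 3 of the 3 values shown sit.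

Compound 4 `CCN1CCN(Cc2ccc(NC(=O)c3cccc(-c4ccc5nc(N)sc5n4)c3)cc2C(F)(F)F)CC1` keeps the core of compound 1 and changes it as follows: (4-ethylpiperazin-1-yl)methyl in place of hydrogen on an aromatic carbon.

The measured steps change a nitrogen, not this aromatic carbon. They are a step that the two limits leave unreadable from compound 1 to compound 2, a step that the two limits leave unreadable from compound 1 to compound 3 and a step that the two limits leave unreadable from compound 2 to compound 3. None gives a usable size, so only a small move toward smaller amounts is expected, if any. The expected step is an at least 1.2-fold lower number from compound 1 to compound 4 (0.09 log units; that floor lies within the scatter). For compound 4 the estimate is 8000 nM, with an expected range of 2500 nM to 20000 nM.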

Compound 4, half-maximal effective concentration: > 10000 nM
Compound 4: no number, only a limit (the forecaster's own chance of this, stated with the estimate: 55%); at least 1.2-fold (0.09 log units) between middle value and limit.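

Compound 4, like compound 1, has only a limit in this assay, so the step between them cannot be read. The compounds shown leave open at what amount any of them would show an effect: the limit of > 10000 nM in this assay, at which 4 of the 4 values shown sit.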